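From compound 3 to compound 4: one group exchanged

A few compounds are considered here, and "the series" means these few. Any claim that something is new, unique, unknown or untested is made for them only; others in the source may bear on it.

Measured in a physicochemical assay for lipophilicity, at pH 7.4; on this read-out lower numbers stand for lower lipophilicity and higher numbers for higher lipophilicity:
Compound 1 `C[C@H]1C(=O)N(C)C=Cc2cc(OC(CO)CO)ccc21`: 1.3
Compound 2 `C[C@H]1C(=O)N(C)C=Cc2cc(CC3CCOCC3)ccc21`: 5.4
Compound 3 `C[C@H]1C(=O)N(C)C=Cc2cc(CN3CCCC3)ccc21`: 1.5

Compound 3, at 1.5, cannot be told apart from compound 1, and both lie far under compound 2, as the step of a number 3.90 log units lower from compound 2 to compound 3 (beyond the scatter) shows. Compound 4 `C[C@H]1C(=O)N(C)C=Cc2cc(C(CO)CO)ccc21` shares the core of compound 3 and differs in one place: 2-hydroxy-1-(hydroxymethyl)ethyl in place of (pyrrolidin-1-yl)methyl on an aromatic carbon. In words, 2-hydroxy-1-(hydroxymethyl)ethyl stands in place of (pyrrolidin-1-yl)methyl on an aromatic carbon.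

Among the compounds with values here, no measured compound carries this exact group. The closest guide is the similarly named 2-hydroxy-1-(hydroxymethyl)ethoxy of compound 1, whose exchange for (pyrrolidin-1-yl)methyl gave a number 0.20 log units higher from compound 1 to compound 3 (within the scatter). Another exchange at this place gave a number 4.10 log units higher from compound 1 to compound 2 (beyond the scatter), so a large step cannot be ruled out. Even so, no step beyond the scatter is expected in this assay. The expected step is a number 0.20 log units lower from compound 3 to compound 4 (within the scatter). For compound 4 the estimate is 1.3, with an expected range from 0.8 to 1.8.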

Compound 4, distribution coefficient: 1.2
Compound 4: the middle estimate sits 0.10 log units above what was measured, within the range that was stated.
By their numbers in this assay, from the lowest: compounds 4, 1 and 3 (each within the scatter of the next); then compound 2.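

In this assay, an open chain with no ring, 2-hydroxy-1-(hydroxymethyl)ethyl, cannot be told apart from the ring-bearing (pyrrolidin-1-yl)methyl, as a number 0.30 log units lower from compound 3 to compound 4 (within the scatter) shows. Exchanging 2-hydroxy-1-(hydroxymethyl)ethoxy for 2-hydroxy-1-(hydroxymethyl)ethyl on this aromatic carbon gives a number 0.10 log units lower from compound 1 to compound 4 (within the scatter) and so no readable change between the ethoxy and ethyl forms of the group. The same new group set against (oxan-4-yl)methyl gives a number 4.20 log units lower from compound 2 to compound 4 (beyond the scatter) and leaves compound 2 as the only one of the four far from the others.

Nothing available explains why these three different groups give such close numbers. On these data alone, it remains open whether a carboxylic acid or a longer chain ending in a single hydroxyl on this aromatic carbon would stay with compounds 1, 3 and 4 or move toward compound 2.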